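Ring swap at the diaryl carbon of the shared core

A few compounds are considered here, and "the series" means these few. Any claim that something is new, unique, unknown or untested is made for them only; others in the source may bear on it.

For the measured compounds named here, compound 2 `O=C(O)Cc1sc(C(c2ccccc2)c2ccc(F)cc2)nc1-c1ccc(Cl)cc1` stands lowest of the two numbers so far in an in vitro functional assay on HEK285-7 cells for antagonist activity at prostaglandin D2 receptor 2 (Homo sapiens), read by BRET and beta-arrestin recruitment (a lower number here means a stronger inhibitor, a higher number a weaker inhibitor), where compound 2 gives 36 nM. Compound 1 `O=C(O)Cc1sc(C(Cc2ccccc2)c2ccccc2)nc1-c1ccc(Cl)cc1` gives 510 nM in this assay, and the step of a 14-fold lower number from compound 1 to compound 2 (1.15 log units; beyond the scatter) is the only measured one. Compound 3 `O=C(O)Cc1sc(C(c2ccccc2)c2ccccn2)nc1-c1ccc(Cl)cc1` carries pyridin-2-yl in place of 4-fluorophenyl on a saturated chain carbon bound to two aromatic carbons. Going by the values given here, no measured step exchanges one aromatic ring for another at that carbon; the step from compound 1 to compound 2 shows only that this position can move the number strongly. A modest weakening is expected for compound 3, a 2.2-fold higher number from compound 2 to compound 3 (0.35 log units; beyond the scatter). Compound 3 is estimated at 80 nM, with a range of 25 nM to 250 nM.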

Compound 3, half-maximal inhibitory concentration: 1900 nM
Compound 3: the middle estimate sits 24-fold (1.38 log units) below what was measured, outside the stated range (above it).
By their numbers in this assay, from the lowest: compound 2; then compound 1; then compound 3.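

At the saturated chain carbon bound to two aromatic carbons, one aromatic ring cannot simply stand in for another: pyridin-2-yl in place of 4-fluorophenyl gives the largest step in the series (a 53-fold higher number from compound 2 to compound 3 (1.72 log units; beyond the scatter)). Pyridin-2-yl also falls behind benzyl (a 3.7-fold higher number from compound 1 to compound 3 (0.57 log units; beyond the scatter)), so the ranking here does not follow from having an aromatic ring on that carbon. Nothing available accounts for either step. Open, as far as these compounds go, is whether plain phenyl in place of 4-fluorophenyl would keep the number near that of compound 2, and how a cyclohexyl ring or a longer chain would read at this carbon.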